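The compounds below may be only part of what the source reports. "The series", "measured", "known", "first", "only" and "open" are said of these compounds alone.

Measured in a functional assay on NCI-H2009 cells (Homo sapiens) for cytotoxicity, read by fluorescence, with a stated time of 48 h; on this read-out higher numbers stand for weaker inhibition of growth and lower numbers for stronger inhibition of growth:
- compound 1 `COc1cc(C(=O)/C=C/c2ccc(O)c(O)c2)cc(OC)c1OC`: 1100 nM
- compound 2 `COc1ccc(/C=C/C(=O)c2cc(OC)c(O)c(OC)c2)cc1O`: 7500 nM
- compound 3 `COc1ccc(/C=C/C(=O)c2cc(OC)c(OC)c(OC)c2)cc1OCCO`: 3300 nM

Compound 1 has the lowest of the three numbers in this assay. Compound 3 lies nearest to it and compound 2 furthest, both beyond the scatter. Among the measured compounds shown here, no measured pair differs in one place only, so the series offers no direct precedent for a single change.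

Compound 4 `COc1cc(C(=O)/C=C/c2ccc(O)cc2)cc(OC)c1OC` has not yet been measured. Relative to compound 1 it carries hydrogen in place of hydroxy on an aromatic carbon, ortho to a hydroxy group, so that 3,4-dihydroxyphenyl becomes 4-hydroxyphenyl. A moderate step to a higher number is expected, although a step within the scatter remains possible. Compound 2 at 7500 nM and compound 3 at 3300 nM both lack the 3,4-dihydroxyphenyl and both stand higher than compound 1, but each also differs from it elsewhere, so this support is indirect.

The estimated change is a 2.7-fold higher number from compound 1 to compound 4 (0.44 log units; beyond the scatter). For compound 4 the estimated value is 3000 nM, with an expected range of 900 nM to 10000 nM.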

Compound 4, concentration for 50% growth inhibition: 4500 nM
Compound 4: middle estimate off by 1.5-fold (0.18 log units), on the low side; low and high end bracket the measured number.
By their numbers in this assay, from the lowest: compound 1; then compounds 3, 4 and 2 (each within the scatter of the next, the first and the last beyond it).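

In this assay, among the compounds shown here, the change from 3,4-dihydroxyphenyl to 4-hydroxyphenyl gives a 4.1-fold higher number from compound 1 to compound 4 (0.61 log units; beyond the scatter), the first direct reading of this position. For the compounds shown here, the step lies beyond the scatter, so the hydroxy group that leaves, ortho to a hydroxy group, counts on the core of compound 1; the earlier compounds could suggest this only indirectly, as each also differed elsewhere. No measurement at hand bears on the origin of this step.

Still open, from the compounds shown here alone, is whether an amine, a fluorine atom or a carboxylic acid at this place would stand nearer compound 1 or compound 4. Equally open, going by these compounds, is how the number would move if the remaining hydroxy of the 4-hydroxyphenyl group in compound 4 gave way to hydrogen.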